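The source may hold more compounds than are shown below. What is called first, only, known or untested is meant among the compounds shown, and "the series" means these compounds.

Compound 1, `Nc1nc2ccccn2c1-c1ccc(O)cc1`, gives > 100000 nM in an assay on isolated protein for inhibition of ubiquitin carboxyl-terminal hydrolase 1 (Homo sapiens) (on this read-out higher numbers stand for weaker inhibition and lower numbers for stronger inhibition), which is a limit of the assay and not a number. Compound 2, `Nc1nc2c(C(F)(F)F)cccn2c1-c1ccc(O)cc1`, gives > 100000 nM in this assay, again a limit of the assay.

Compound 1 therefore stands nowhere definite on the numbers shown: both values rest at the limit of > 100000 nM in this assay, at which 2 of the 2 values shown sit, so its inhibition is known only to be weaker than that limit. Among the compounds with values here, the one change measured so far, trifluoromethyl in place of hydrogen on an aromatic carbon, gave a step that the two limits leave unreadable from compound 1 to compound 2.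

Compound 3, `Cc1ccc2nc(N)c(-c3ccc(O)cc3)n2c1`, differs from compound 1 by methyl in place of hydrogen on an aromatic carbon. Within the data shown here, the only measured step that bears on such a small change on this ring is the one from compound 1 to compound 2, and its size cannot be read. Among the measured compounds shown here, no step in this assay beyond the scatter is therefore expected, and the result is expected to come back as a limit. Compound 3 is estimated at 150000 nM, within 30000 nM to 600000 nM. The expected step is a step that the limit leaves unreadable from compound 1 to compound 3.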

Compound 3, half-maximal inhibitory concentration: > 100000 nM
Compound 3 gave a limit, no number (the forecaster's own chance of this, stated with the estimate: 85%); the middle value lies beyond the limit too.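

No new step can be read between compound 1 and compound 3, as each gives a limit of the assay and not a number: the limit of > 100000 nM in this assay, at which 3 of the 3 values shown sit.

The compounds shown leave open how large the effect of methyl or trifluoromethyl on the core of compound 1 is in this assay.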